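One Chlorine Fewer on the Phenoxy Ring

This account rests on a few compounds, and the source may have more. Where it says the series, first, only, none or still open, it means among the compounds named here.

compound 1 `Cc1cn(C2CCN(Cc3cccc(Oc4cc(Cl)cc(Cl)c4)c3)CC2)c(=O)[nH]c1=O`: 6730 nM
compound 2 `Cc1cn(C2CCN(Cc3ccnc(Oc4ccccc4)c3)CC2)c(=O)[nH]c1=O`: > 64000 nM, a limit of the assay rather than a number

Both values come from an ADME assay on MRC5 cells (Homo sapiens) for cytotoxicity, read by fluorescence and resazurin assay, with a stated time of 3 days; on this read-out higher numbers stand for weaker inhibition and lower numbers for stronger inhibition. Compound 1 holds the only number shown in this assay; the other value sits at a limit, (the limit of > 64000 nM in this assay, at which 1 of the 2 values shown sits). Compound 3 `Cc1cn(C2CCN(Cc3cccc(Oc4cccc(Cl)c4)c3)CC2)c(=O)[nH]c1=O` differs from compound 1 by hydrogen in place of chloro on an aromatic carbon. No step between two measured compounds is shown, so the size of this change is not measured. For compound 3 a moderate weakening is expected, a 2.2-fold higher number from compound 1 to compound 3 (0.35 log units; beyond the scatter). Compound 3 is therefore estimated at 15000 nM, in the range 5000 nM to 60000 nM.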

Compound 3, half-maximal inhibitory concentration: 21000 nM
Compound 3: middle estimate off by 1.4-fold (0.15 log units), on the low side, and the stated range covers the measured number.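

Taking one chloro out of the 3,5-dichlorophenoxy group gives, in this assay, a 3.1-fold higher number from compound 1 to compound 3 (0.49 log units; beyond the scatter), so this position on the phenoxy ring is not indifferent to the change. The 3-chlorophenoxy group of compound 3 therefore reads as weaker inhibition of the cells than the 3,5-dichlorophenoxy group of compound 1. Nothing shown here gives a reason for this step. On these data alone, whether the remaining chloro counts for as much stays open. So does how a fluoro or a methoxy group at the vacated position would read.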